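A few compounds are considered here, and "the series" means these few. Any claim that something is new, unique, unknown or untested is made for them only; others in the source may bear on it.

Among the compounds with values here, compound 2 `Cc1nc2c(N)ncnc2n1[C@@H]1O[C@H](CN(C)CCCCON)[C@@H](O)[C@H]1O` gives 5 nM in an assay on isolated protein for inhibition of S-adenosylmethionine decarboxylase proenzyme (Homo sapiens) (on this read-out higher numbers stand for weaker inhibition and lower numbers for stronger inhibition), and it holds the lowest of the two numbers measured so far. Its nearest neighbour is compound 1 `Cc1nc2c(N)ncnc2n1[C@@H]1O[C@H](C[S+](C)C)[C@@H](O)[C@H]1O`, which in this assay gives 3000 nM; the step between them is a 600-fold lower number from compound 1 to compound 2 (2.78 log units; beyond the scatter), brought about by the exchange of the sulfonium-bearing group for the longer chain carrying the amine and the aminooxy end.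

Compound 3 `Cc1nc2c(N)ncnc2n1[C@@H]1O[C@H](CN(C)CCCN)[C@@H](O)[C@H]1O` differs from compound 2 in one place: amino in place of (aminooxy)methyl on a saturated chain carbon, three bonds along the chain from an amine nitrogen. The chain is thereby shortened and its terminal aminooxy is replaced by a plain amine. Within the data shown here, no measured step covers this exchange; the only step available concerns the installation of the whole chain, and that step was large. Because the entire gain from compound 1 to compound 2 came with the aminooxy-terminated chain a 600-fold lower number from compound 1 to compound 2 (2.78 log units; beyond the scatter), removing that end is expected to give back part of that gain, and compound 3 is expected to show a weaker result, a step of a 100-fold higher number from compound 2 to compound 3 (2.00 log units; beyond the scatter). Compound 3 is estimated to give 500 nM, with a range from 50 nM to 5000 nM.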

Compound 3, half-maximal inhibitory concentration: 70000 nM
The estimate for compound 3 lay 140-fold (2.15 log units) below the measured number, outside the stated range (above it).
By their numbers in this assay, from the lowest: compound 2; then compound 1; then compound 3.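

At this position the end of the chain decides the outcome: in this assay, the exchange of 4-(aminooxy)butyl for 3-aminopropyl on the amine nitrogen gives a step (a 14000-fold higher number from compound 2 to compound 3 (4.15 log units; beyond the scatter)) that is larger than the whole gain seen when the aminooxy-terminated chain took the place of the sulfonium-bearing group (a 600-fold lower number from compound 1 to compound 2 (2.78 log units; beyond the scatter)). An amine-bearing chain at this position therefore does not bring the gain by itself, for the 3-aminopropyl chain moves the number the other way relative to the sulfonium-bearing group (a 23-fold higher number from compound 1 to compound 3 (1.37 log units; beyond the scatter)). The data offer no measured explanation for how much this one change matters.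

The compounds shown leave open how much of the loss belongs to the shorter chain and how much to the replacement of the aminooxy end by a plain amine, as both changed in the same step. A 4-aminobutyl chain, which keeps the longer chain with a plain amine, and a 3-(aminooxy)propyl chain, which keeps the aminooxy end on a shorter chain, would separate these two parts.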